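Replacing bromo with phenyl on the azetidinylmethoxy pyridine core

The source may hold more compounds than are shown below. What is called first, only, known or untested is meant among the compounds shown, and "the series" means these compounds.

Measured so far in an assay on brain for binding affinity to Neuronal acetylcholine receptor; alpha4/beta2 (Rattus norvegicus), read by radioligand binding; a higher number here means a weaker inhibitor, a lower number a stronger inhibitor:
- compound 1, `Brc1ccc(OC[C@@H]2CCN2)cn1`, gives 0.021 nM
- compound 2, `Clc1cncc(OC[C@@H]2CCN2)c1`, gives 0.042 nM
- compound 3, `Brc1cncc(OC[C@@H]2CCN2)c1`, gives 0.18 nM

Compound 3 has the highest number of the three, so it is the weakest binder of the set: compound 2 sits nearest with a lower number, and compound 1 is furthest away with the lowest number of all. Among the measured compounds shown here, the one single-point step among the measured compounds is a 4.3-fold higher number from compound 2 to compound 3 (0.63 log units; beyond the scatter), a change of halogen at the same aromatic carbon, and it moved the number upward.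

Compound 4, `c1ccc(-c2cncc(OC[C@@H]3CCN3)c2)cc1`, is the next compound to be measured in this assay. It differs from compound 3 in one place: phenyl in place of bromo on an aromatic carbon. For the measured compounds named here, no measured pair in this set shows bromo giving way to phenyl, so the only guidance is indirect. The step from chloro to bromo already raised the number beyond the scatter, and phenyl is a much larger group than either halogen at this position. A further rise in the number is therefore expected, modest in size rather than dramatic. The expected step is a 5.6-fold higher number from compound 3 to compound 4 (0.74 log units; beyond the scatter). For compound 4 the expected value is 1 nM, with a range from 0.2 nM to 5 nM.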

Compound 4, inhibition constant: 0.046 nM
For compound 4 the middle estimate is 22-fold (1.34 log units) above the measured one; measured number below the stated range.
By their numbers in this assay, from the lowest: compounds 1, 2 and 4 (each within the scatter of the next, the first and the last beyond it); then compound 3.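

In this assay, this aromatic carbon accepts far more than a single halogen atom: with 6 heavy atoms and a whole aromatic ring entering where bromo had 1 heavy atom, the result is a 3.9-fold lower number from compound 3 to compound 4 (0.59 log units; beyond the scatter). Compared with chloro, the same phenyl group gives a 1.1-fold higher number from compound 2 to compound 4 (0.04 log units; within the scatter), which lies within the scatter, so the earlier rise on going from chloro to bromo, a 4.3-fold higher number from compound 2 to compound 3 (0.63 log units; beyond the scatter), does not continue as a steady climb with the number of heavy atoms at this position. Nothing in the available data explains why phenyl and chloro cannot be told apart here while bromo stands apart from both.

The compounds shown leave open how other groups would behave at this carbon, such as a pyridyl ring, a phenyl ring carrying a methoxy group, or a simple methyl group. They also leave open whether phenyl would give a similar result on the aromatic carbon that carries bromo in compound 1.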